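Toward a 2-chlorophenyl group in the cytotoxicity test

The compounds below may be only part of what the source reports. "The series", "measured", "known", "first", "only" and "open" are said of these compounds alone.

The study concerns two measured compounds and one that is not yet measured. Going by the values given here, compound 1, `COc1ccc(-c2cnc(NC(=O)c3ccc(F)cc3)[nH]2)cc1`, is the first of them. In a toxicity assay on THP-1 cells (Homo sapiens) for inhibition (on this read-out higher numbers stand for lower toxicity in this test and lower numbers for higher toxicity in this test), compound 1 gives only a limit of the assay, > 100000 nM. Compound 2, `COc1ccc(-c2cnc(NC(=O)c3cnco3)n2C)cc1`, is the second. In this assay compound 2 also gives only a limit of the assay, > 100000 nM. Compound 2 thus stands where every value shown stands, because the limit of > 100000 nM in this assay, at which 2 of the 2 values shown sit, holds both of them. Among the compounds with values here, no step between measured compounds is known here. Compound 3, `COc1ccc(-c2cnc(NC(=O)c3ccccc3Cl)n2C)cc1`, differs from compound 2 in one place: 2-chlorophenyl in place of 1,3-oxazol-5-yl on a carbonyl carbon. Since compound 2 sits at a limit, as the limit of > 100000 nM in this assay, at which 2 of the 2 values shown sit, records, no step beyond the usual scatter is expected, and the estimated step is a number no higher from compound 2 to compound 3 (the limit leaves the size open). Compound 3 is therefore expected to give about 100000 nM in this assay, within a range from 30000 nM to 300000 nM, most likely again as a limit.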

Compound 3, half-maximal cytotoxic concentration: > 50000 nM
Compound 3: no number, only a limit; the forecaster's own chance of this, stated with the estimate: 75%; the middle value lies beyond the limit too.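

The step from compound 2 to compound 3 cannot be read in this assay: both results are limits of the assay, not numbers. The compounds shown leave open whether 2-chlorophenyl in place of 1,3-oxazol-5-yl on a carbonyl carbon changes the read-out at all.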